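Trifluoromethoxy in Place of Trifluoromethyl on the Aromatic Ring

A few compounds are considered here, and "the series" means these few. Any claim that something is new, unique, unknown or untested is made for them only; others in the source may bear on it.

Three measured compounds share a core and differ only in the group on the carbonyl carbon. Compound 1 `O=C(Nc1ccc(C(F)(F)F)c(F)c1)NC1CCN(C(=O)C2(C(F)(F)F)CC2)CC1` carries a 1-(trifluoromethyl)cyclopropyl group there; in a physicochemical assay for lipophilicity, read by HPLC, with a stated time of 90 min, tested at 100 uM (a higher number here means a more lipophilic compound, a lower number a more polar compound), compound 1 gives 5.52, the highest of the three numbers. Compound 2 `O=C(Nc1ccc(C(F)(F)F)c(F)c1)NC1CCN(C(=O)[C@@H]2CCOC2)CC1` gives 3.41, and compound 3 `O=C(Nc1ccc(C(F)(F)F)c(F)c1)NC1CCN(C(=O)C2CCOCC2)CC1` gives 3.52. Both steps away from compound 1 are large: a number 2.11 log units lower from compound 1 to compound 2 (beyond the scatter) and a number 2.00 log units lower from compound 1 to compound 3 (beyond the scatter). Between the two smaller groups the difference is a number 0.11 log units higher from compound 2 to compound 3 (within the scatter), within the scatter.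

Compound 4 `O=C(Nc1ccc(OC(F)(F)F)c(F)c1)NC1CCN(C(=O)C2(C(F)(F)F)CC2)CC1` keeps the 1-(trifluoromethyl)cyclopropyl group and instead changes the aromatic ring: trifluoromethoxy in place of trifluoromethyl on an aromatic carbon. Among the compounds with values here, none of the measured steps touches this place; all three exchange the group on the carbonyl carbon, so they show only how much that other position can move the number and give no direct guide here. With nothing measured at the aromatic ring, the expectation rests on the change itself being a swap of one small group for a closely related one, so a step within the scatter, or at most slightly upward, is expected. Compound 4 is therefore estimated at 5.65, with a range from 5.25 to 6.05. That estimate means an expected step of a number 0.13 log units higher from compound 1 to compound 4 (within the scatter).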

Compound 4, partition coefficient: 5.94
The estimate for compound 4 lay 0.29 log units below the measured number, within the range that was stated.
By their numbers in this assay, from the lowest: compounds 2 and 3 (each within the scatter of the next); then compound 1; then compound 4.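

The aromatic carbon changed here is not a silent position: in this assay there is a number 0.42 log units higher from compound 1 to compound 4 (beyond the scatter) when trifluoromethyl, with its 4 heavy atoms and no hydrogen-bond acceptor, gives way to trifluoromethoxy, with 5 heavy atoms and 1 hydrogen-bond acceptor. The result is the first reading at this place, and it shows a real but smaller movement than the exchange on the carbonyl carbon, where the listed change gives a number 2.11 log units lower from compound 1 to compound 2 (beyond the scatter) and so remains the larger of the two kinds of change in this small set. Nothing among the data shown accounts for the upward step, so it stands as an observation only.

As far as these compounds go, this single step was read with the 1-(trifluoromethyl)cyclopropyl group in place, so it remains open whether trifluoromethoxy would give a similar step alongside the oxan-4-yl or oxolan-3-yl group on the carbonyl carbon. From the compounds shown here alone, it is also open how the number would respond at this aromatic carbon to a different group, such as a methoxy group, a nitrile or a chlorine atom.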